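The source may hold more compounds than are shown below. What is called first, only, known or untested is meant among the compounds shown, and "the series" means these compounds.

Working notes on the series

The three measured compounds share one core. Compound 1 has the structure `CC(C)[C@H]1CC[C@@](O)(CI)[C@H]2C(=O)OCC(C(=O)O)=C[C@H]12` and compound 2 the structure `CC(C)[C@H]1CC[C@@](O)(CO)[C@H]2C(=O)OCC(C(=O)O)=C[C@H]12`; they differ in one place, hydroxy in place of iodo on a saturated chain carbon bound to a saturated ring carbon. In a functional assay on A-375 cells (Homo sapiens) for inhibition, with a stated time of 72 h (on this read-out lower numbers stand for stronger inhibition and higher numbers for weaker inhibition), compound 1 gives > 10000 nM, which is a limit of the assay and not a number. Compound 2 gives > 32000 nM in this assay, again only a limit. The step that the two limits leave unreadable from compound 1 to compound 2 therefore cannot be read, since both ends sit at limits, namely the limit of > 10000 nM in this assay, at which 1 of the 3 values shown sits, and (the limit of > 32000 nM in this assay, at which 1 of the 3 values shown sits).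

Compound 3, of structure `COC(=O)C1=C[C@@H]2[C@@H](C(C)C)CC[C@@]3(CO3)[C@H]2C(=O)OC1`, gives 4090 nM in this assay. Going by the values given here, this is the only number among the three values shown. Compound 4, of structure `CNC(=O)C1=C[C@@H]2[C@@H](C(C)C)CC[C@@]3(CO3)[C@H]2C(=O)OC1`, is not yet measured and differs from compound 3 by methylamino in place of methoxy on a carbonyl carbon.

Among the compounds with values here, no measured step touches the group on this carbonyl carbon; the single measured step, a step that the two limits leave unreadable from compound 1 to compound 2, is unreadable and lies elsewhere on the core. With nothing to lean on, no shift beyond the usual scatter is expected, so the step of a 1.0-fold lower number from compound 3 to compound 4 (0.01 log units; within the scatter) is estimated to stay small. Compound 4 is accordingly expected to give about 4000 nM in this assay, within 1300 nM to 12000 nM.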

Compound 4, half-maximal inhibitory concentration: 4150 nM
Compound 4: middle estimate off by 1.0-fold (0.02 log units), on the low side; the range from low to high includes it.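

In this assay, methylamino in place of methoxy on a carbonyl carbon gives a 1.0-fold higher number from compound 3 to compound 4 (0.01 log units; within the scatter). Going by these compounds alone, this is the first readable step, and it shows that at this carbonyl carbon, whose other neighbour is a double-bonded ring carbon, the change from methoxycarbonyl to methylcarbamoyl leaves the read-out within the scatter, even though the two groups differ in their hydrogen-bond donor and acceptor counts. Nothing measured on these compounds bears on why the two values sit so close together.

The compounds shown leave open whether this tolerance extends to other groups on the same carbonyl carbon, such as ethoxy, dimethylamino or benzylamino, since a single pair cannot define a trend at this position. They also leave open whether the same exchange would give a similar result on the other cores shown here, as the only other step, the one between the two compounds reported as limits, cannot be read.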